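Replacing the Methoxyphenyl Arm: What to Expect for Compound 4

The source may report more compounds than this note shows. Statements on the series, on what has been measured and on what is new or still open speak of the compounds shown alone.

Going by the values given here, compound 3 `COc1ccc(-c2cn(-c3cccc(C(=O)/C=C/c4ccc(O)c(OC)c4)c3)nn2)cc1` gives 7900 nM in a functional assay on RAW264.7 cells (Mus musculus) for inhibition, with a stated time of 4 days (a lower number here means a stronger inhibitor, a higher number a weaker inhibitor), the lowest of the three numbers so far. Compound 2 `COc1cc(/C=C/C(=O)c2cccc(-n3cc(-c4ccc(C)cc4)nn3)c2)ccc1O` gives 15400 nM in this assay, and the step of a 1.9-fold lower number from compound 2 to compound 3 (0.29 log units; within the scatter) lies within the scatter. Compound 1 `COc1cc(/C=C/C(=O)c2cccc(-n3cc(-c4ccccc4)nn3)c2)ccc1O` gives 16800 nM in this assay, and the step of a 2.1-fold lower number from compound 1 to compound 3 (0.33 log units; beyond the scatter) is modest but beyond the scatter. Compound 4 `COc1cc(/C=C/C(=O)c2cccc(-n3cc(-c4ccccc4C(F)(F)F)nn3)c2)ccc1O` differs from compound 3 by 2-(trifluoromethyl)phenyl in place of 4-methoxyphenyl on an aromatic carbon. The step of a 2.1-fold lower number from compound 1 to compound 3 (0.33 log units; beyond the scatter) bears most on this change, since the methoxy that entered there now leaves; the step of a 1.1-fold lower number from compound 1 to compound 2 (0.04 log units; within the scatter) shows a methyl changing little. Among the compounds with values here, no measured compound carries a trifluoromethyl group. Because the step of a 2.1-fold lower number from compound 1 to compound 3 (0.33 log units; beyond the scatter) would be undone, compound 4 is expected to show a 1.8-fold higher number from compound 3 to compound 4 (0.25 log units; within the scatter), an estimated 14000 nM in the range 6000 nM to 35000 nM.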

Compound 4, half-maximal inhibitory concentration: 5070 nM
The estimate for compound 4 lay 2.8-fold (0.44 log units) above the measured number; the measured number lies below the stated range.
By their numbers in this assay, from the lowest: compounds 4, 3, 2 and 1 (each within the scatter of the next, the first and the last beyond it).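

In this assay, the step of a 1.6-fold lower number from compound 3 to compound 4 (0.19 log units; within the scatter) stays within the scatter, so at this position 2-(trifluoromethyl)phenyl can stand in for 4-methoxyphenyl without a measurable change, and the methoxy is not required for a number of this size. The steps of a 3.3-fold lower number from compound 1 to compound 4 (0.52 log units; beyond the scatter) and a 3.0-fold lower number from compound 2 to compound 4 (0.48 log units; beyond the scatter) are both modest but beyond the scatter, showing that a group on the phenyl other than methoxy can also lower the number. Nothing available explains these steps.

The compounds shown leave open whether the trifluoromethyl group itself or its place on the ring accounts for these steps, which a 4-(trifluoromethyl)phenyl arm would help separate. From the compounds shown here alone, how an amine or a carboxylic acid on this arm would read also remains open.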